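The compounds below may be only part of what the source reports. "The series", "measured", "known", "first", "only" and "open" are said of these compounds alone.

Compound 1, `COC(=O)c1ccc2c(ccn2-c2ccc(NC(=O)c3ccc(Cl)c(C(F)(F)F)c3)cc2)n1`: 3000 nM
Compound 2, `NC(=O)c1ccc2c(ccn2-c2ccc(NC(=O)c3cccc(C(F)(F)F)c3)cc2)n1`: > 10000 nM (a limit, not a number)
Compound 3, `COC(=O)c1ccc2c(ccn2-c2ccc(NC(=O)Nc3cccc(Cl)c3Cl)cc2)n1`: 6400 nM

In a functional assay on A375P cells (Homo sapiens) for cytotoxicity, read by MTT assay (a higher number here means a weaker inhibitor, a lower number a stronger inhibitor), compound 1 gives 3000 nM and compound 3 gives 6400 nM. Among the compounds with values here, compound 3 thus holds the highest of the two numbers, and the single measured step leading to it is a 2.1-fold higher number from compound 1 to compound 3 (0.33 log units; beyond the scatter). For compound 2 the reading is a limit only, (the limit of > 10000 nM in this assay, at which 1 of the 3 values shown sits); it gives no number to compare.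

The unmeasured compound 4, `NC(=O)c1ccc2c(ccn2-c2ccc(NC(=O)Nc3cccc(Cl)c3Cl)cc2)n1`, differs from compound 3 by amino in place of methoxy on a carbonyl carbon. Within the data shown here, no measured pair isolates this exchange, so no step speaks to it directly. Compound 2 carries the same amino group on its carbonyl carbon as compound 4 does, but it also differs from compound 4 elsewhere, and in this assay compound 2 reaches only the limit > 10000 nM. That is thin evidence, yet it is the only hint available, and it points towards a higher number rather than a lower one.

Compound 4 is therefore expected to sit somewhat above compound 3, a step of about a 1.7-fold higher number from compound 3 to compound 4 (0.24 log units; within the scatter). The estimate for compound 4 in this assay is 11000 nM, within a range from 4000 nM to 30000 nM, with a real chance that only a limit is reported.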

Compound 4, half-maximal inhibitory concentration: 4600 nM
For compound 4 the middle estimate is 2.4-fold (0.38 log units) above the measured one, and the stated range covers the measured number.
By their numbers in this assay, from the lowest: compounds 1, 4 and 3 (each within the scatter of the next, the first and the last beyond it). At a limit, above all of these: compound 2.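

In this assay, within the data shown here, this is the first pair that isolates amino in place of methoxy on a carbonyl carbon, and it gives a 1.4-fold lower number from compound 3 to compound 4 (0.14 log units; within the scatter), so with the rest of the molecule held fixed, the exchange leaves no difference that can be told from the scatter. Compound 2 also carries the amino group but yields no number, only a limit: the limit of > 10000 nM in this assay, at which 1 of the 4 values shown sits. With the amino group now present on both sides of the comparison, the change of 3-(trifluoromethyl)phenyl to (2,3-dichlorophenyl)amino on a carbonyl carbon gives an at least 2.1-fold lower number from compound 2 to compound 4 (0.33 log units; beyond the scatter), which shows that in this pair the amino group alone does not hold a compound at the limit and that the other end of the molecule also matters.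

From the compounds shown here alone, this rests on a single matched pair, so it remains open whether methoxy and amino would also read alike with the 4-chloro-3-(trifluoromethyl)phenyl group of compound 1 at the other end. The compounds shown also leave open what a hydroxy group, which would make a carboxylic acid, or a dimethylamino group would give on the same carbonyl carbon.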